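Methyl for Cyclopropyl on a Sulfonyl Sulfur

The source may hold more compounds than are shown below. What is called first, only, known or untested is meant among the compounds shown, and "the series" means these compounds.

In an ADME assay on microsomes from liver (Homo sapiens) for metabolic stability, with a stated time of 10 min, tested at 0.5 uM (a higher number here means that more of the compound is left, a lower number that less of the compound is left), compound 1 `CC(C)Cc1ccc(-c2cn(C)c3cc(C(=O)NS(C)(=O)=O)ccc23)cc1` gives 100% and compound 2 `Cn1cc(-c2ccc(C(F)(F)F)cc2)c2ccc(C(=O)NS(=O)(=O)C3CC3)cc21` gives 87%, the lower of the two numbers by more than the usual scatter. Compound 3 `Cn1cc(-c2ccc(C(F)(F)F)cc2)c2ccc(C(=O)NS(C)(=O)=O)cc21` has methyl in place of cyclopropyl on a sulfonyl sulfur and is otherwise the same as compound 2. Compound 1 also carries methylsulfonyl, and its 100% offers no hint of a drop. The expected a number 5 percentage points higher from compound 2 to compound 3 (within the scatter) is a small rise, within the scatter of this assay as it is usually seen. For compound 3 the estimate is 92%, with a range from 80% to 100% of the compound left.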

Compound 3, percent of the compound remaining: 100%
The estimate for compound 3 lay 8 percentage points below the measured number, and the stated range covers the measured number.
By their numbers in this assay, from the lowest: compound 2; then compounds 1 and 3 (each within the scatter of the next).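

In this assay the sulfonyl sulfur proves to be a position that matters: with trifluoromethyl held constant, methyl in place of cyclopropyl gives a number 13 percentage points higher from compound 2 to compound 3 (beyond the scatter). With methylsulfonyl held constant, trifluoromethyl in place of isobutyl on an aromatic carbon gives no change at the digits printed from compound 1 to compound 3 (within the scatter), so this second change shows no measurable effect here. The data shown offer no explanation for the difference between methyl and cyclopropyl. Still open, going by these compounds, is where an ethyl group or a longer chain on the sulfonyl sulfur would fall, and whether an amine there would keep as much compound intact.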